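Swapping a fluorinated phenyl ring for a pyridine ring

The source may hold more compounds than are shown below. What is called first, only, known or untested is meant among the compounds shown, and "the series" means these compounds.

Compound 3 `Cc1c(F)cccc1N(C)C(=O)c1ccc(-c2ccc(O)cc2)o1` was tested in an assay on cytosol from placenta for inhibition of 17-beta-hydroxysteroid dehydrogenase type 2 (Homo sapiens), read by HPLC, using microsomes, with a stated time of 10 min, in the presence of a further agent that is not named here (a lower number here means a stronger inhibitor, a higher number a weaker inhibitor), where compound 3 gives 3900 nM. Among the compounds with values here, this is the highest of the three numbers measured so far, though every gap to the others lies within the scatter: compound 2 `Cc1cccc(F)c1N(C)C(=O)c1ccc(-c2ccc(O)cc2)o1` gives 3200 nM in this assay, and compound 1 `Cc1ccccc1N(C)C(=O)c1ccc(-c2cccc(O)c2)o1` gives 2800 nM. Within the data shown here, the one step between neighbours that differ in a single place, a 1.2-fold higher number from compound 2 to compound 3 (0.09 log units; within the scatter), is within the scatter.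

Compound 4 `Cc1ncccc1N(C)C(=O)c1ccc(-c2ccc(O)cc2)o1` has not yet been measured. It differs from compound 3 in one place: 2-methylpyridin-3-yl in place of 3-fluoro-2-methylphenyl on an amide-type nitrogen. Among the measured compounds shown here, no measured step swaps a carbon-only ring for a ring holding a nitrogen; the only measured step, a 1.2-fold higher number from compound 2 to compound 3 (0.09 log units; within the scatter), merely moves a fluorine around a carbon-only ring and does not bear directly on this change. There is thus no measured basis for expecting a move beyond the scatter in either direction. The expected value for compound 4 in this assay is estimated at 4000 nM, within a range from 1300 nM to 12000 nM. The expected step of a 1.0-fold higher number from compound 3 to compound 4 (0.01 log units; within the scatter) is estimated to stay within the scatter.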

Compound 4, half-maximal inhibitory concentration: > 30000 nM
Compound 4 was reported as a limit (the forecaster's own chance of this, stated with the estimate: 5%); middle value at least 7.5-fold (0.87 log units) from the limit.
By their numbers in this assay, from the lowest: compounds 1, 2 and 3 (each within the scatter of the next). At a limit, above all of these: compound 4.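

In this assay, replacing the fluorinated carbon-only ring with 2-methylpyridin-3-yl on the amide-type nitrogen gives an at least 7.6-fold higher number from compound 3 to compound 4 (0.88 log units; beyond the scatter), and the same comparison from the other fluorinated ring gives an at least 9.3-fold higher number from compound 2 to compound 4 (0.97 log units; beyond the scatter). Moving the fluorine around the ring had stayed within the scatter, with a 1.2-fold higher number from compound 2 to compound 3 (0.09 log units; within the scatter), so these are the first steps shown at this position to weaken inhibition beyond the scatter, and the position clearly does not accept every six-membered aromatic ring. Compound 4 is reported only as a limit: the limit of > 30000 nM in this assay, at which 1 of the 4 values shown sits.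

Compound 4 gains a ring nitrogen and loses the fluorine in one change, so the compounds shown cannot separate these two effects. From the compounds shown here alone, it also remains open whether a methoxy group or an amine on the carbon-only ring would keep inhibition in the range of compound 2 and compound 3.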